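The compounds below may be only part of what the source reports. "The series", "measured", "known", "first", "only" and "open" are said of these compounds alone.

Compound 2 `COC(=O)N(COC(=O)[C@@H](C)c1ccc2cc(OC)ccc2c1)c1ccccc1` and compound 1 `CCn1cc(C(=O)OCN(C)C(=O)OC)c(=O)c2ccc(C)nc21` were both examined in a physicochemical assay for metabolic stability; on this read-out lower numbers stand for a shorter-lived compound and higher numbers for a longer-lived compound. Compound 2 gives 1.99 h, the highest of the two numbers shown. Compound 1 gives 0.667 h, which is lower than the number for compound 2 by more than the usual scatter of repeated measurements, so the two compounds are clearly separated on this read-out. Compound 3 `CCOC(=O)c1ccc(N(COC(=O)[C@@H](C)c2ccc3cc(OC)ccc3c2)C(=O)OC)cc1` has not yet been measured. It differs from compound 2 in one place: ethoxycarbonyl in place of hydrogen on an aromatic carbon. Among the compounds with values here, no pair of measured compounds here shows what such a change does to the half-life, so the expectation for compound 3 rests only on its closeness to compound 2. The step from compound 2 to compound 3 in this assay is expected to be small, a 1.2-fold lower number from compound 2 to compound 3 (0.09 log units; within the scatter), and may not exceed the scatter. Compound 3 is therefore estimated at 1.6 h, with a plausible range from 0.6 h to 4 h.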

Compound 3, half-life: 2.61 h
Beside the measured number, compound 3's estimate is 1.6-fold (0.21 log units) below it; measured number inside the range.
By their numbers in this assay, from the lowest: compound 1; then compounds 2 and 3 (each within the scatter of the next).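

In this assay, the change from phenyl to 4-(ethoxycarbonyl)phenyl gives a 1.3-fold higher number from compound 2 to compound 3 (0.12 log units; within the scatter). Within the data shown here, this is the first comparison here between two compounds that differ in only one place, and it shows that a group of 5 heavy atoms can sit on this aromatic carbon, para to a large group, without moving the half-life beyond the scatter. Nothing available gives a reason for this result.

From the compounds shown here alone, it remains open whether a carboxylic acid, an amine or a longer chain at the same place would also leave the half-life within the scatter of compound 2. A single substituent at a single place also cannot tell whether ethoxycarbonyl would behave the same way on another carbon of this ring.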